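Replacing the Aryl Group on the Amide of Compound 1

A few compounds are considered here, and "the series" means these few. Any claim that something is new, unique, unknown or untested is made for them only; others in the source may bear on it.

In a functional assay on MGC-803 cells (Homo sapiens) for inhibition, read by MTT assay, with a stated time of 72 h (on this read-out lower numbers stand for stronger inhibition and higher numbers for weaker inhibition), compound 1 (`CC(C)c1ccc(NC(=O)C2CCN(C/C=C/c3ccccc3)CC2)cc1`) gives 5200 nM and compound 3 (`O=C(Nc1cccc(C(F)(F)F)c1)C1CCN(C/C=C/c2ccccc2)CC1`) gives 9590 nM as a pair within the usual scatter of each other. Compound 2 (`COc1ccccc1NC(=O)C1CCN(C/C=C/c2ccccc2)CC1`) stands well apart at 71200 nM as the highest of the three numbers.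

Compound 4 (`O=C(Nc1ccc(F)c(Br)c1)C1CCN(C/C=C/c2ccccc2)CC1`) differs from compound 1 in one place (3-bromo-4-fluorophenyl in place of 4-isopropylphenyl on an amide-type nitrogen), with 3-bromo-4-fluorophenyl in place of 4-isopropylphenyl on an amide-type nitrogen. Going by the values given here, the one measured step at this place is large (a 14-fold higher number from compound 1 to compound 2 (1.14 log units; beyond the scatter)) and shows that the group on this nitrogen can matter. Among the compounds with values here, that step brings in a 2-methoxyphenyl, however, and no measured compound carries the incoming group. The nearest guide is the halogen-bearing relative compound 3 at 9590 nM, in the same range as compound 1. A modest shift towards a higher number is therefore expected, with nothing foreseen beyond the scatter. The expected step is a 1.4-fold higher number from compound 1 to compound 4 (0.16 log units; within the scatter) on this reasoning. Compound 4 is estimated at 7500 nM with 2800 nM to 20000 nM as its expected range.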

Compound 4, half-maximal inhibitory concentration: 9270 nM
Estimate against measurement, compound 4: 1.2-fold (0.09 log units) below, and the stated range covers the measured number.
By their numbers in this assay, from the lowest: compounds 1, 4 and 3 (each within the scatter of the next); then compound 2.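

In this assay, a second replacement of the 4-isopropylphenyl group on the amide-type nitrogen, this time by 3-bromo-4-fluorophenyl, gives a 1.8-fold higher number from compound 1 to compound 4 (0.25 log units; within the scatter), so this change cannot be told from the scatter. The other new step, a 7.7-fold lower number from compound 2 to compound 4 (0.89 log units; beyond the scatter), shows that the high number of compound 2 does not follow from every replacement of the 4-isopropylphenyl group and sets the 2-methoxyphenyl compound apart from compound 4 as well as from compound 1. Nothing shown here gives a cause for either step.

The compounds shown leave open whether an amine or a carboxylic acid on this phenyl group, or a longer alkyl chain in its place, would move the number beyond the scatter. They also do not separate the effect of the methoxy group itself from that of its location on the phenyl group in compound 2.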